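This account rests on a few compounds, and the source may have more. Where it says the series, first, only, none or still open, it means among the compounds named here.

Measured compounds, with their values in a functional assay on aorta (Rattus norvegicus); a lower number here means a stronger inhibitor, a higher number a weaker inhibitor:

Compound 1 `O=c1ccc(CO)nn1Cc1ccccc1`: compound 1 gives > 100000 nM, a limit of the assay.
Compound 2 `O=c1ccc(CCOCc2ccccc2)nn1Cc1ccccc1`: compound 2 gives 32300 nM.
Compound 3 `CC(C)(C)[Si](OCCCc1ccc(=O)[nH]n1)(c1ccccc1)c1ccccc1`: compound 3 gives 78300 nM.

Of the two numbers actually reported in this assay, compound 2 has the lower one; compound 3 sits beyond the scatter above it. Compound 1 reports no number at all, only (the limit of > 100000 nM in this assay, at which 1 of the 3 values shown sits), so it cannot be ranked against the others beyond noting that it is the weakest entry in this set.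

The next compound is compound 4 `O=c1ccc(CCO)nn1Cc1ccccc1`, which differs from compound 2 in one place: hydrogen in place of benzyl on an oxygen on a saturated carbon. Compound 1, the other member of this set carrying a free hydroxy on a saturated chain, reached only the assay limit, whereas compound 2 with its benzyl ether gave a measurable value. The step from compound 2 to compound 4 is therefore expected to go toward a higher number, and by a margin beyond the scatter, with a real chance that compound 4 also comes back as a limit. The expected step is a 2.8-fold higher number from compound 2 to compound 4 (0.45 log units; beyond the scatter). For compound 4 in this assay the estimate is 90000 nM, within a range from 30000 nM to 300000 nM.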

Compound 4, half-maximal inhibitory concentration: > 100000 nM
Compound 4: no number, only a limit; the forecaster's own chance of this, stated with the estimate: 45%; middle value at least 1.1-fold (0.04 log units) away from the limit.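

In this assay, going by these compounds alone, benzyloxy to hydroxy on the saturated chain is the first change that can be read in one place, and it gives an at least 3.0-fold higher number from compound 2 to compound 4 (0.49 log units; beyond the scatter). Compound 4 gives > 100000 nM, which is a limit of the assay, so the printed size of this step is a lower bound only, and the measurable value of compound 2 depends on the benzyl on that oxygen. The step between compound 1 and compound 4, which differ in the hydroxymethyl and hydroxy groups, cannot be read, so nothing can be said about the chain carrying a free hydroxy, and the limit now holds both of these compounds: the limit of > 100000 nM in this assay, at which 2 of the 4 values shown sit.

Going by these compounds, it remains open whether the benzyl ring itself matters or whether any group on that oxygen would serve, which a methyl ether or a phenyl ether on the same chain would separate. Also open, on these data alone, is how an amine or a carboxylic acid at the end of that chain would read in this assay, and whether any such group would bring a number lower than that of compound 2.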